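A few compounds are considered here, and "the series" means these few. Any claim that something is new, unique, unknown or untested is made for them only; others in the source may bear on it.

Among the measured compounds shown here, compound 2 `CCc1ccc(C(=O)Nc2cccc(-c3oc4cc(-c5ccc(F)cc5)ccc4c(=O)c3O)c2)cc1` gives 18500 nM in a functional assay on A549 cells (Homo sapiens) for antiproliferative activity, read by CCK-8 assay, with a stated time of 72 h (a lower number here means a stronger inhibitor, a higher number a weaker inhibitor), the higher of the two numbers measured so far, though within the scatter of compound 1 `COc1ccccc1C(=O)Nc1cccc(-c2oc3cc(-c4ccc(F)cc4)ccc3c(=O)c2O)c1`, which gives 11700 nM; the step of a 1.6-fold higher number from compound 1 to compound 2 (0.20 log units; within the scatter) is the only one recorded. Compound 3 `O=C(Nc1cccc(-c2oc3cc(-c4ccc(F)cc4)ccc3c(=O)c2O)c1)c1ccc(-c2ccccc2)cc1` differs from compound 2 by phenyl in place of ethyl on an aromatic carbon. For the measured compounds named here, the one measured step also exchanges the aryl on the carbonyl carbon and stays within the scatter, so a step of a 1.2-fold lower number from compound 2 to compound 3 (0.06 log units; within the scatter) is expected, no larger than the scatter in either direction. Compound 3 is therefore estimated at 16000 nM, with a range from 6000 nM to 42000 nM.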

Compound 3, half-maximal inhibitory concentration: > 100000 nM
Compound 3 was reported as a limit (the forecaster's own chance of this, stated with the estimate: 15%); middle value at least 6.2-fold (0.79 log units) from the limit.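

In this assay compound 3 is reported only as a limit of the assay, not as a number: the limit of > 100000 nM in this assay, at which 1 of the 3 values shown sits. Phenyl in place of ethyl at this aromatic carbon, para to a large group, gives an at least 5.4-fold higher number from compound 2 to compound 3 (0.73 log units; beyond the scatter). The 4-phenylphenyl group likewise gives an at least 8.5-fold higher number from compound 1 to compound 3 (0.93 log units; beyond the scatter), so the aryl on the carbonyl carbon can matter here, although the earlier step stayed within the scatter.

As far as these compounds go, the true size of both steps stays open. Also open, from the compounds shown here alone, is how a longer chain such as butyl, a methoxy group or an amine would read at this carbon.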